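Amide-aryl variation on a pyridinyl-pyrimidine anilide series

The source may hold more compounds than are shown below. What is called first, only, known or untested is meant among the compounds shown, and "the series" means these compounds.

The shared core of compound 1 `COc1ccc(C(=O)Nc2cc(Br)cc(C(F)(F)F)c2)cc1Nc1nccc(-c2cccnc2)n1` carries an anilide whose aryl group is varied. Going by the values given here, in a functional assay on K562 cells (Homo sapiens) for antiproliferative activity, read by MTT assay, with a stated time of 48 h (on this read-out lower numbers stand for stronger inhibition and higher numbers for weaker inhibition), compound 1 gives 215000 nM, and compound 2 `COc1cccc(NC(=O)c2ccc(OC)c(Nc3nccc(-c4cccnc4)n3)c2)c1` gives 93100 nM; the only step measured, a 2.3-fold lower number from compound 1 to compound 2 (0.36 log units; beyond the scatter), is a modest one. For compound 3 `COc1ccc(C(=O)Nc2ccc(Br)cc2)cc1Nc1nccc(-c2cccnc2)n1` the entry in this assay reads "not determined" (no result reported), so compound 3 stands nowhere on the scale. Compound 4 `COc1ccc(C(=O)Nc2ccncc2)cc1Nc1nccc(-c2cccnc2)n1` differs from compound 3 by pyridin-4-yl in place of 4-bromophenyl on an amide-type nitrogen. Among the compounds with values here, no measured step bears directly on this change, and the one available step is modest, so the expectation for compound 4 in this assay is a number in the same weak region as compounds 1 and 2, without a confident direction. Compound 4 is therefore estimated at 150000 nM, with a range from 50000 nM to 400000 nM.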

Compound 4, half-maximal inhibitory concentration: 94500 nM
Compound 4: middle estimate off by 1.6-fold (0.20 log units), on the high side; low and high end bracket the measured number.
By their numbers in this assay, from the lowest: compounds 2 and 4 (each within the scatter of the next); then compound 1.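

In this assay a ring with a hetero atom on the amide-type nitrogen is not separated from 3-methoxyphenyl, with a 1.0-fold higher number from compound 2 to compound 4 (0.01 log units; within the scatter), and a 2.3-fold lower number from compound 1 to compound 4 (0.36 log units; beyond the scatter) shows that pyridin-4-yl, like 3-methoxyphenyl, sits modestly clear of 3-bromo-5-(trifluoromethyl)phenyl. The step from 4-bromophenyl to pyridin-4-yl cannot be read, since compound 3 has no result. Nothing available explains these numbers. Still open, on these data alone, is whether an aminophenyl, a carboxyphenyl or a saturated piperidine ring at this nitrogen would leave this weak region of the scale.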